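Swapping an Aromatic Arm for a Short Chain

The source may hold more compounds than are shown below. What is called first, only, known or untested is meant among the compounds shown, and "the series" means these compounds.

Measured compounds in an ADME assay on NIH3T3 cells (Homo sapiens) for cytotoxicity, read by sulforhodamine B assay, with a stated time of 48 h; a higher number here means a weaker inhibitor, a lower number a stronger inhibitor:
Compound 1, `CC(=O)OC[C@H]1O[C@@H](n2cc(Cn3cc(/C=C4/C(=O)Nc5ccccc54)c4ccccc43)nn2)[C@H](OC(C)=O)[C@@H](OC(C)=O)[C@@H]1OC(C)=O`, gives the limit > 200000 nM.
Compound 2, `COc1ccc(/C=C2\C(=O)N(Cc3cn([C@@H]4O[C@H](COC(C)=O)[C@@H](OC(C)=O)[C@H](OC(C)=O)[C@H]4OC(C)=O)nn3)c3ccccc32)cc1OC`, gives the limit > 100000 nM.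
Compound 3, `CC(=O)OC[C@H]1O[C@@H](n2cc(CN3C(=O)/C(=C/c4ccc5ccccc5c4)c4ccccc43)nn2)[C@H](OC(C)=O)[C@@H](OC(C)=O)[C@@H]1OC(C)=O`, gives 28400 nM.

In this assay compound 2 stands at a limit and not at a number, namely (the limit of > 100000 nM in this assay, at which 1 of the 3 values shown sits). Compound 1 also stands at a limit, namely (the limit of > 200000 nM in this assay, at which 1 of the 3 values shown sits). Going by the values given here, compound 3 is the one compound with a measured number. Among the compounds with values here, no two measured compounds differ in a single place, so no measured step can be counted from the data.

Compound 4, `CCC/C=C1\C(=O)N(Cc2cn([C@@H]3O[C@H](COC(C)=O)[C@@H](OC(C)=O)[C@H](OC(C)=O)[C@H]3OC(C)=O)nn2)c2ccccc21`, differs from compound 2 by one change: propyl in place of 3,4-dimethoxyphenyl on a double-bonded chain carbon bound to a double-bonded ring carbon. With compound 2 only at a limit, the step from compound 2 to compound 4 is expected to be a step that the limit leaves unreadable from compound 2 to compound 4, that is, no move beyond the usual scatter, and a limit is again the most likely outcome. Compound 4 is therefore expected at 150000 nM, within 40000 nM to 600000 nM.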

Compound 4, half-maximal inhibitory concentration: > 100000 nM
Compound 4: a limit, no number (the forecaster's own chance of this, stated with the estimate: 70%); the middle value does not contradict the limit.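

In this assay, compound 2 and compound 4 both stand at a limit and not at a number, and the step between them cannot be read. The compounds shown leave open whether propyl in place of 3,4-dimethoxyphenyl changes the result in this assay at all.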